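The source may hold more compounds than are shown below. What is called first, only, known or untested is meant among the compounds shown, and "the series" means these compounds.

Measured so far:
- compound 1 `N/C(=N\NC(=S)N1CCOCC1)c1ccc(F)cn1`: 12.4%
- compound 2 `N/C(=N\NC(=S)N1CCOCC1)c1ccccn1`: 14.7%

In a functional assay on MCF7 cells (Homo sapiens) for cytotoxicity, read by MTT assay, with a stated time of 72 h, tested at 1 uM (a lower number here means less inhibition of growth, a higher number more inhibition of growth at the concentration tested), compound 2 holds the larger of the two numbers, yet the gap a number 2.3 percentage points higher from compound 1 to compound 2 (within the scatter) lies within the scatter, so the two compounds are not truly separated. Compound 3 `N/C(=N\NC(=S)N1CCCC1)c1ccccn1` changes a different part of the molecule: pyrrolidin-1-yl in place of morpholin-4-yl on a thiocarbonyl carbon. Among the compounds with values here, no measured step touches the ring on the thiocarbonyl carbon; the single measured step concerns the fluoro and is itself within the scatter, so it gives no guide. With that, the step of a number 0.7 percentage points lower from compound 2 to compound 3 (within the scatter) is expected to stay within the scatter. Compound 3 is therefore estimated at 14%, in the range 3% to 27%.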

Compound 3, percent growth inhibition at one concentration: 45.9%
For compound 3 the middle estimate is 31.9 percentage points below the measured one, and the stated range ends below it.
By their numbers in this assay, from the lowest: compounds 1 and 2 (each within the scatter of the next); then compound 3.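

At the thiocarbonyl carbon, the ring clearly matters: in this assay, pyrrolidin-1-yl in place of morpholin-4-yl gives a number 31.2 percentage points higher from compound 2 to compound 3 (beyond the scatter), whereas the fluoro step did not separate its two compounds. Within the data shown here, this change shrinks the ring and removes its oxygen at once, so the single step cannot show which of the two counts. No measured evidence here accounts for the rise.

A piperidin-1-yl ring, with six members and no oxygen, would help to separate ring size from the oxygen. As far as these compounds go, whether fluoro changes the number when pyrrolidin-1-yl is present remains open.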